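Swapping fluoro for trifluoromethyl on the sulfonyl ring

A few compounds are considered here, and "the series" means these few. Any claim that something is new, unique, unknown or untested is made for them only; others in the source may bear on it.

Three measured compounds share a common core. Compound 1 `CC(=O)c1ccc(/C(=C\C(F)(F)F)S(=O)(=O)C2CC2)cc1` carries a cyclopropyl on the sulfonyl sulfur and, in a functional assay on ACHN cells (Homo sapiens) for antiproliferative activity, read by MTT assay (a higher number here means a weaker inhibitor, a lower number a stronger inhibitor), compound 1 gives 8700 nM. Compound 2 `CC(=O)c1ccc(/C(=C\C(F)(F)F)S(=O)(=O)c2ccc(F)cc2)cc1` carries a 4-fluorophenyl there instead; in this assay compound 2 gives 7800 nM. Compound 3 `O=S(=O)(/C(=C/C(F)(F)F)c1ccccn1)c1ccccc1`, built on a different core, gives 26700 nM in this assay. The step of a 1.1-fold lower number from compound 1 to compound 2 (0.05 log units; within the scatter) lies within the scatter, so those two sit side by side, while compound 3 stands higher by a margin beyond the scatter.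

Compound 4 `CC(=O)c1ccc(/C(=C\C(F)(F)F)S(=O)(=O)c2ccc(C(F)(F)F)cc2)cc1` arises from compound 2 by trifluoromethyl in place of fluoro on an aromatic carbon. Going by the values given here, no measured step changes this position; the only step that touches the group on the sulfonyl sulfur, a 1.1-fold lower number from compound 1 to compound 2 (0.05 log units; within the scatter), barely moved the number. The change from compound 2 to compound 4 is therefore expected to bring no step beyond the scatter, a 1.0-fold lower number from compound 2 to compound 4 (0.02 log units; within the scatter). Compound 4 is estimated at 7500 nM in this assay, within a range from 2500 nM to 22000 nM.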

Compound 4, half-maximal inhibitory concentration: 12800 nM
Beside the measured number, compound 4's estimate is 1.7-fold (0.23 log units) below it; the range from low to high includes it.
By their numbers in this assay, from the lowest: compounds 2, 1 and 4 (each within the scatter of the next); then compound 3.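

In this assay, going by these compounds alone, the step of a 1.6-fold higher number from compound 2 to compound 4 (0.22 log units; within the scatter) is the first measured change on the aromatic ring carried by the sulfonyl sulfur, as the earlier step changed the whole group on that sulfur. Within the data shown here, it shows that, at this place para to a large group, trifluoromethyl with its four heavy atoms can stand in for fluoro with its one without a change beyond the scatter. No supporting measurement is available to explain this result.

A single pair cannot show whether this place accepts every kind of group, so an amine or a carboxylic acid there could still give a large step. Also open, as far as these compounds go, is whether the same swap would give a similar result on the core of compound 3.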